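A Change on the Sulfonyl Sulfur

The compounds below may be only part of what the source reports. "The series", "measured", "known", "first", "only" and "open" are said of these compounds alone.

Of the compounds shown here, three have been measured in a physicochemical assay for solubility, in phosphate buffer, with a stated time of 24 h, at pH 7.4, tested at 100 uM; a higher number here means a more soluble compound, a lower number a less soluble compound. Compound 1 (`O=C(NCc1ccc(S(=O)(=O)c2ccccc2)cc1)N1Cc2cccnc2C1`) gives 144000 nM. Compound 2 (`O=S(=O)(c1ccccc1)c1ccc(CNS(=O)(=O)N2Cc3ccncc3C2)cc1`) gives 3000 nM. Compound 3 (`CCCn1cc(S(=O)(=O)c2ccc(CNC(=O)N3Cc4ccncc4C3)cc2)cn1`) gives 105000 nM, which lies within the scatter of compound 1 and well beyond the scatter above compound 2.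

Compound 4 (`CC(=O)N1CCC(S(=O)(=O)c2ccc(CNC(=O)N3Cc4ccncc4C3)cc2)CC1`) has 1-acetylpiperidin-4-yl in place of 1-propyl-1H-pyrazol-4-yl on a sulfonyl sulfur. Among the compounds with values here, no measured pair differs in one place only, so the data give no direct guide to this change. The expected outcome is no step beyond the scatter, with an estimated step of a 1.1-fold lower number from compound 3 to compound 4 (0.02 log units; within the scatter). For compound 4 the estimated value is 100000 nM, with an expected range from 40000 nM to 170000 nM.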

Compound 4, solubility: 187000 nM
Estimate against measurement, compound 4: 1.9-fold (0.27 log units) below; the whole stated range lies below it.
By their numbers in this assay, from the lowest: compound 2; then compounds 3, 1 and 4 (each within the scatter of the next).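

Read in this assay, the change on the sulfonyl sulfur gives a 1.8-fold higher number from compound 3 to compound 4 (0.25 log units; within the scatter) and is the first direct comparison at this position. An aromatic 1-propyl-1H-pyrazol-4-yl and a non-aromatic 1-acetylpiperidin-4-yl therefore cannot be told apart here, although the two rings differ in size and in hetero atoms. No measurement shown explains this result. The compounds shown leave open how a free amine or a carboxylic acid on the group at this sulfonyl sulfur would read.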